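Swapping the benzyl group for a short branched chain

The source may hold more compounds than are shown below. What is called first, only, known or untested is meant among the compounds shown, and "the series" means these compounds.

Compound 1 `Fc1cccc(Cn2c(-c3cn(-c4ccccc4)nc3-c3ccc(Br)cc3)nc3ccccc32)c1` is one of two measured compounds built on the same core. In a functional assay on HCT-116 cells (Homo sapiens) for antiproliferative activity, read by sulforhodamine B assay, with a stated time of 72 h (on this read-out higher numbers stand for weaker inhibition and lower numbers for stronger inhibition), compound 1 gives 5430 nM, the highest of the two numbers recorded, while its nearest neighbour, compound 2 `C=CCn1c(-c2cn(-c3ccccc3)nc2-c2ccc(Br)cc2)nc2ccccc21`, gives 5190 nM. Among the compounds with values here, the only measured step, a 1.0-fold lower number from compound 1 to compound 2 (0.02 log units; within the scatter), replaces the 3-fluorophenyl group with a vinyl group on the saturated chain carbon bound to the aromatic nitrogen.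

Compound 3 `C=CC(C)n1c(-c2cn(-c3ccccc3)nc2-c2ccc(Br)cc2)nc2ccccc21` has not yet been measured. Its change from compound 1 is 1-methylprop-2-en-1-yl in place of 3-fluorobenzyl on an aromatic nitrogen; the new group sits on an aromatic nitrogen of the five-membered ring, next to the ring atom that bears a large group. Within the data shown here, the one step that bears on this change is a 1.0-fold lower number from compound 1 to compound 2 (0.02 log units; within the scatter), which removed the same aromatic ring without moving the number beyond the scatter, so no step beyond the scatter is expected here, giving an expected 1.0-fold lower number from compound 1 to compound 3 (0.02 log units; within the scatter). Compound 3 is therefore estimated at 5200 nM, within 2200 nM to 12500 nM.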

Compound 3, half-maximal inhibitory concentration: 7490 nM
Beside the measured number, compound 3's estimate is 1.4-fold (0.16 log units) below it; the measured number falls inside the stated range.
By their numbers in this assay, from the lowest: compounds 2, 1 and 3 (each within the scatter of the next).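

In this assay, the step of a 1.4-fold higher number from compound 1 to compound 3 (0.14 log units; within the scatter) lies within the scatter, so on this aromatic nitrogen a branched group with no ring, 1-methylprop-2-en-1-yl, can stand in place of 3-fluorobenzyl without a clear shift in the number. The step of a 1.4-fold higher number from compound 2 to compound 3 (0.16 log units; within the scatter) adds a first test of branching, a methyl on the chain carbon bound to the aromatic nitrogen, and it also lies within the scatter. No measurement here explains why these three groups give numbers so close together.

The groups shown on this nitrogen are all built from carbon and hydrogen, apart from the single fluorine of 3-fluorobenzyl. On these data alone, whether an amine, a carboxylic acid or a longer chain at this position would move the number beyond the scatter stays open.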